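A few compounds are considered here, and "the series" means these few. Any claim that something is new, unique, unknown or untested is made for them only; others in the source may bear on it.

Compound 3 `COC(=O)CCc1ccc(S(=O)(=O)NNc2ccc(Br)cc2)cc1` stands second highest of the three numbers in an assay on HeLa cells for inhibition of Indoleamine 2,3-dioxygenase 1 (Homo sapiens), read by spectrophotometry, with a stated time of 24 h; on this read-out lower numbers stand for an effect already at smaller amounts and higher numbers for an effect only at larger amounts of compound: compound 3 gives 465 nM, compound 2 `CC(=O)Nc1ccc(S(=O)(=O)NNc2ccc(Br)cc2)cc1` gives 85 nM, and compound 1 `Cc1cccc(NNS(=O)(=O)c2ccc(S(C)(=O)=O)cc2)c1` gives 7850 nM. Compound 4 `O=C(O)c1ccc(S(=O)(=O)NNc2ccc(Br)cc2)cc1` differs from compound 3 in one place: carboxy in place of 2-(methoxycarbonyl)ethyl on an aromatic carbon. Within the data shown here, no measured pair shows carboxy entering or 2-(methoxycarbonyl)ethyl leaving on that ring; the only step that bears on this position is the one from compound 2 to compound 3, a 5.5-fold higher number from compound 2 to compound 3 (0.74 log units; beyond the scatter), which shows that exchanging the group on this aromatic carbon, para to a large group, moves this assay by a modest amount beyond the scatter. A change of similar size, in either direction, therefore seems plausible for compound 4, and the direction cannot be read from the compounds measured. The estimate for compound 4 in this assay is 1200 nM, within a range of 300 nM to 6000 nM, which amounts to an expected step of a 2.6-fold higher number from compound 3 to compound 4 (0.41 log units; beyond the scatter).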

Compound 4, half-maximal effective concentration: 172 nM
Beside the measured number, compound 4's estimate is 7.0-fold (0.84 log units) above it; the measured number lies below the stated range.
By their numbers in this assay, from the lowest: compound 2; then compound 4; then compound 3; then compound 1.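

In this assay, exchanging 2-(methoxycarbonyl)ethyl for carboxy on this aromatic carbon gives a 2.7-fold lower number from compound 3 to compound 4 (0.43 log units; beyond the scatter), so the longer chain is not needed here for a number in this range, and the first change seen to lower the number at this position leaves a free carboxy group in place. Acetamido still gives the lowest number of the three groups at this position, with a 2.0-fold higher number from compound 2 to compound 4 (0.31 log units; beyond the scatter), which places carboxy between acetamido and 2-(methoxycarbonyl)ethyl, each step beyond the scatter. Nothing at hand accounts for this order.

This single change shortens the chain and replaces the ester with the acid at once, so the compounds shown do not separate the two. Where methoxycarbonyl directly on the ring, a propanoic acid chain or an amine would fall in this order remains open.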